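From 2-methoxyphenyl to 2,4-dimethoxyphenyl: a step near the limit

The source may report more compounds than this note shows. Statements on the series, on what has been measured and on what is new or still open speak of the compounds shown alone.

Compound 1 (`COc1cc(C(=O)c2sc3ccccc3c2-c2ccccc2)cc(OC)c1OC`) gives 5000 nM
Compound 2 (`COc1cc(C(=O)c2sc3ccccc3c2-c2ccc(Cl)cc2)cc(OC)c1OC`) gives 7500 nM
Compound 3 (`COc1ccccc1-c1c(C(=O)c2cc(OC)c(OC)c(OC)c2)sc2ccccc12`) gives > 10000 nM as a limit
Compound 4 (`COc1ccc(-c2c(C(=O)c3cc(OC)c(OC)c(OC)c3)sc3ccccc23)c(OC)c1`) has not yet been measured

These values come from a functional assay on A549 cells (Homo sapiens) for antiproliferative activity, read by MTT assay, with a stated time of 72 h (on this read-out lower numbers stand for stronger inhibition and higher numbers for weaker inhibition), and form a very small set. Compound 3 has no number of its own and rests on the limit of > 10000 nM in this assay, at which 1 of the 3 values shown sits, as its only standing.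

Compound 4 carries methoxy in place of hydrogen on an aromatic carbon, para to a large group and meta to the existing methoxy group, which turns 2-methoxyphenyl into 2,4-dimethoxyphenyl (methoxy in place of hydrogen on an aromatic carbon).

Going by the values given here, the closest precedent is the same kind of replacement in an at least 2.0-fold higher number from compound 1 to compound 3 (0.30 log units; that floor lies within the scatter) and its size is known only as a floor. Chloro in place of hydrogen gives a 1.5-fold higher number from compound 1 to compound 2 (0.18 log units; within the scatter) and the exchange of the aryl groups gives an at least 1.3-fold higher number from compound 2 to compound 3 (0.12 log units; that floor lies within the scatter) as a further floor. None of these steps shows a change beyond the scatter, so no clear step is expected in this assay for this change. The expected step, as estimated, is a number no higher from compound 3 to compound 4 (the limit leaves the size open) and it stays small. For compound 4 the value is estimated at 10000 nM with an expected range from 4000 nM to 25000 nM and the assay may well report only a limit again.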

Compound 4, half-maximal inhibitory concentration: 5800 nM
For compound 4 the middle estimate is 1.7-fold (0.24 log units) above the measured one, and the stated range covers the measured number.
By their numbers in this assay, from the lowest: compounds 1, 4 and 2 (each within the scatter of the next). At a limit, above all of these: compound 3.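

In this assay, the 2,4-dimethoxyphenyl group of compound 4 gives a measured number where the 2-methoxyphenyl group of compound 3 gave only a limit, a change read as an at least 1.7-fold lower number from compound 3 to compound 4 (0.23 log units; that floor lies within the scatter). Compound 4 also cannot be told apart from the compounds without this methoxy group, with a 1.3-fold lower number from compound 2 to compound 4 (0.11 log units; within the scatter) and a 1.2-fold higher number from compound 1 to compound 4 (0.06 log units; within the scatter), so the added methoxy group, para to a large group, leaves the number among theirs. The true size of the step from the 2-methoxyphenyl group cannot be read, since compound 3 rests on a limit alone: the limit of > 10000 nM in this assay, at which 1 of the 4 values shown sits.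

The compounds shown leave open whether an amine or a hydroxy group in this place would move the number beyond the scatter. They also leave open what a methoxy group in this place would do on the phenyl ring of compound 1, without the other methoxy group.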